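Phenyl to cyclohexyl in a cell toxicity test

The source may hold more compounds than are shown below. What is called first, only, known or untested is meant among the compounds shown, and "the series" means these compounds.

Measured in an ADME assay on MRC5 cells (Homo sapiens) for cytotoxicity, read by fluorescence and resazurin assay, with a stated time of 3 days; on this read-out higher numbers stand for weaker inhibition and lower numbers for stronger inhibition:
- compound 1 `Cc1cn(C2CCN(Cc3cccc(Oc4ccc(Cl)cc4)c3)CC2)c(=O)[nH]c1=O`: 25100 nM
- compound 2 `Cc1ccc(Oc2cccc(CN3CCC(n4cc(C)c(=O)[nH]c4=O)CC3)c2)cc1`: > 64000 nM
- compound 3 `Cc1cn(C2CCN(Cc3cccc(Oc4ccccc4)c3)CC2)c(=O)[nH]c1=O`: "not determined" (no result reported)

Compound 3 has no number in this assay, as no result was reported for it. For the measured compounds named here, the only guides are the two compounds that were measured. Compound 1 gives 25100 nM, a weak effect on this read-out. Compound 2 sits at the limit of > 64000 nM in this assay, at which 1 of the 3 values shown sits, which is a limit and not a number.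

Compound 4 `Cc1cn(C2CCN(Cc3cccc(OC4CCCCC4)c3)CC2)c(=O)[nH]c1=O` differs from compound 3 by a single change: cyclohexyl in place of phenyl on an oxygen on an aromatic ring. In words, this is cyclohexyl in place of phenyl on an oxygen on an aromatic ring.

Going by the values given here, one measured step bears on this, and only loosely: an at least 2.5-fold higher number from compound 1 to compound 2 (0.40 log units; beyond the scatter), with methyl in place of chloro on an aromatic carbon. That step shows that a small edit can move the number beyond the usual scatter, but it is a different kind of change. Compound 3 also offers no starting value. Among the compounds with values here, no step of a definite size or direction can therefore be expected, only a position in the same weak region as compound 1 at 25100 nM. For compound 4 the expected value is 35000 nM, with an estimated range from 14000 nM to 64000 nM.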

Compound 4, half-maximal inhibitory concentration: 23600 nM
Compound 4: the middle estimate sits 1.5-fold (0.17 log units) above what was measured, and the stated range covers the measured number.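

Putting cyclohexyl on the oxygen in place of 4-chlorophenyl gives a 1.1-fold lower number from compound 1 to compound 4 (0.03 log units; within the scatter), so in this assay compound 4 shows that an aromatic ring at this place is not required for a number in the same weak region as that of compound 1. Putting the same cyclohexyl in place of 4-methylphenyl gives an at least 2.7-fold lower number from compound 2 to compound 4 (0.43 log units; beyond the scatter), which shows that replacing an aromatic ring with this saturated ring has no single outcome here: the result depends on which aromatic ring leaves, and the two substituted phenyl compounds do not give one shared baseline. The value of compound 2 is a limit and not a number, so that step has only a minimum size: the limit of > 64000 nM in this assay, at which 1 of the 4 values shown sits.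

Compound 3 has no reported result, so the step from the unsubstituted phenyl to cyclohexyl, the most direct comparison at this position, cannot be read. The compounds shown also leave open how the number would respond to a smaller ring such as cyclopentyl, to an open chain such as butyl, or to a cyclohexyl ring carrying an amine or a carboxylic acid.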